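Working notes: pyridyl alkenoic acids in a thromboxane synthase assay

This account rests on a few compounds, and the source may have more. Where it says the series, first, only, none or still open, it means among the compounds named here.

Measured so far:
- compound 1 `CSC(CCC/C=C(\c1ccccc1)c1cccnc1)C(=O)O`, 30 nM
- compound 2 `Cc1ccsc1/C(=C/CCCCC(=O)O)c1cccnc1`, 29 nM
- compound 3 `O=C(O)CCCCCC(c1ccccc1)c1cccnc1`, 2700 nM

In an assay (Equus caballus) for inhibition of Thromboxane-A synthase (Homo sapiens), using microsomes (a higher number here means a weaker inhibitor, a lower number a stronger inhibitor), compound 1 gives 30 nM and stands second highest of the three numbers. Its nearest neighbour is compound 2, whose value of 29 nM lies within the scatter of that of compound 1, so no order can be read between these two. Among the compounds with values here, the furthest is compound 3 at 2700 nM, a gap that is well beyond the scatter; compound 3 is the only member without a double bond outside the aromatic rings.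

The next compound, compound 4 `O=C(O)CCC/C=C(\c1ccccc1)c1cccnc1`, has not been measured in this assay. Against compound 1 the change is carboxy in place of carboxy(methylsulfanyl)methyl on a saturated chain carbon, three bonds along the chain from a double-bonded chain carbon. Within the data shown here, no step between measured compounds carries this change, so its size is unknown here. The acid moves closer to the double-bonded chain carbon and the methylsulfanyl group is gone; a shift to a weaker inhibitor seems more likely than a stronger one, with the step from compound 1 to compound 4 expected at a 5.0-fold higher number from compound 1 to compound 4 (0.70 log units; beyond the scatter). Compound 4 is estimated at 150 nM, within a range of 30 nM to 800 nM.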

Compound 4, half-maximal inhibitory concentration: 30 nM
For compound 4 the middle estimate is 5.0-fold (0.70 log units) above the measured one; the measured number falls inside the stated range.
By their numbers in this assay, from the lowest: compounds 2, 1 and 4 (each within the scatter of the next); then compound 3.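

In this assay, within the data shown here, the first step at this place reads no change at the digits printed from compound 1 to compound 4 (within the scatter), the only reading so far of carboxy in place of carboxy(methylsulfanyl)methyl on a saturated chain carbon, three bonds along the chain from a double-bonded chain carbon. With this core, the number therefore does not depend on the methylsulfanyl group or on the larger acid-bearing group, and the plain carboxy group serves equally well at this place. No measurement available here bears on why the number holds.

Still open, from the compounds shown here alone, is whether a methyl ester or an amide in place of carboxy would keep the number. Going by these compounds, it is also open whether a longer chain carrying the carboxy group would behave as this single step does.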